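Adding a sulfonyl group to the ring nitrogen of compound 3

This account rests on a few compounds, and the source may have more. Where it says the series, first, only, none or still open, it means among the compounds named here.

In a functional assay on HepG2 cells (Homo sapiens) for cytotoxicity, read by MTT assay, with a stated time of 24 h (a higher number here means a weaker inhibitor, a lower number a stronger inhibitor), compound 1 `CN1C/C(=C\c2ccncc2)C(=O)/C(=C/c2ccccc2F)C1` stands at 4600 nM and compound 2 `O=C1/C(=C/c2cccnc2)CNC/C1=C\c1ccccc1F` at 21000 nM while compound 3 `O=C1/C(=C/c2cccnc2)CNC/C1=C\c1ccccc1C(F)(F)F` stands at 5020 nM in the same read-out. Compound 3 and compound 1 lie within the scatter of each other, and compound 2 carries a clearly higher number than compound 3.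

Compound 4 `O=C1/C(=C/c2cccnc2)CN(S(=O)(=O)c2ccc(Cl)cc2)C/C1=C\c1ccccc1C(F)(F)F` departs from compound 3 at one place: (4-chlorophenyl)sulfonyl in place of hydrogen on an amine nitrogen in a ring with (4-chlorophenyl)sulfonyl in place of hydrogen on the amine nitrogen in the ring.

For the measured compounds named here, the only measured step, a 4.2-fold lower number from compound 2 to compound 3 (0.62 log units; beyond the scatter) on an aromatic carbon, is modest and lies elsewhere, so it offers only a rough scale. Going by the values given here, no measured pair isolates a change on that nitrogen. Compound 1 has a group there and gives 4600 nM in this assay but differs from compound 2 in more than one place. A modest step towards a lower number is therefore expected, with wide uncertainty. The estimated step is a 2.5-fold lower number from compound 3 to compound 4 (0.40 log units; beyond the scatter) in this assay for now. Compound 4 is expected at 2000 nM (estimated range 500 nM to 7000 nM).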

Compound 4, half-maximal inhibitory concentration: 3620 nM
For compound 4 the middle estimate is 1.8-fold (0.26 log units) below the measured one; measured number inside the range.
By their numbers in this assay, from the lowest: compounds 4, 1 and 3 (each within the scatter of the next); then compound 2.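

The single-place step at the amine nitrogen in the ring is a 1.4-fold lower number from compound 3 to compound 4 (0.14 log units; within the scatter) in this assay, so this position now has a direct reading. With the trifluoromethyl compounds, the free hydrogen on that nitrogen can give way to the much larger (4-chlorophenyl)sulfonyl, with its added aromatic ring and two hydrogen-bond acceptors, and the read-out stays within the scatter. Nothing available explains this outcome or links it to any property of the group.

As far as these compounds go, it remains open whether a smaller group on the same nitrogen, such as acetyl or methanesulfonyl, or a sulfonyl group carrying methoxy in place of the chlorine, would give a step beyond the scatter. The pair also leaves open whether the same replacement gives a similar step when fluoro stands in place of trifluoromethyl on the other aromatic ring.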